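A Methyl-Bearing Benzyl Group Replaces 4-Fluorobenzyl

The source may report more compounds than this note shows. Statements on the series, on what has been measured and on what is new or still open speak of the compounds shown alone.

In a functional assay on PC-3 cells (Homo sapiens) for inhibition, read by MTT assay, with a stated time of 48 h (on this read-out higher numbers stand for weaker inhibition and lower numbers for stronger inhibition), compound 1 (`COc1cc(N(Cc2ccc(Cl)cc2)S(=O)(=O)c2ccc(C)cc2)cc(OC)c1OC`) gives 14600 nM and compound 2 (`COc1cc(N(Cc2ccc(F)cc2)S(=O)(=O)c2ccc(C)cc2)cc(OC)c1OC`) gives 20700 nM. Among the measured compounds shown here, compound 2 therefore stands level with compound 1, the only other measured compound, and the numbers do not separate the two.

Compound 3 (`COc1cc(N(Cc2cccc(C)c2)S(=O)(=O)c2ccc(C)cc2)cc(OC)c1OC`) has not yet been measured. It differs from compound 2 as follows: 3-methylphenyl in place of 4-fluorophenyl on a saturated chain carbon bound to a sulfonamide nitrogen. Put simply, 3-methylphenyl stands in place of 4-fluorophenyl on a saturated chain carbon bound to a sulfonamide nitrogen.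

For the measured compounds named here, only one measured step bears on this change. Fluoro in place of chloro on an aromatic carbon, going from compound 1 to compound 2, gave a 1.4-fold higher number from compound 1 to compound 2 (0.15 log units; within the scatter). That step is only a loose guide, since neither measured compound carries the 3-methylphenyl group. With nothing larger measured in this small set, no step beyond the scatter is expected in this assay, and no direction can be favoured with confidence. The expected change is a 1.2-fold lower number from compound 2 to compound 3 (0.06 log units; within the scatter). Compound 3 is estimated at 18000 nM, within an expected range of 7000 nM to 45000 nM.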

Compound 3, half-maximal inhibitory concentration: 8580 nM
Estimate against measurement, compound 3: 2.1-fold (0.32 log units) above; the measured number falls inside the stated range.
By their numbers in this assay, from the lowest: compounds 3, 1 and 2 (each within the scatter of the next, the first and the last beyond it).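

In this assay, the place on a saturated chain carbon bound to a sulfonamide nitrogen now gives its first step beyond the scatter: 3-methylphenyl in place of 4-fluorophenyl gave a 2.4-fold lower number from compound 2 to compound 3 (0.38 log units; beyond the scatter), a modest step, whereas the earlier exchange of chloro for fluoro had not separated its two compounds. The same group in place of 4-chlorophenyl gave a 1.7-fold lower number from compound 1 to compound 3 (0.23 log units; within the scatter), so compound 3 is not separated from compound 1, and the difference holds only against compound 2. Nothing available explains the step.

As far as these compounds go, the change from 4-fluorophenyl to 3-methylphenyl alters both the substituent and its ring position at once, so what each contributes stays open, and a 4-methylphenyl or 3-fluorophenyl group at this place would be needed to tell them apart. Also open, from the compounds shown here alone, is how an amine or a carboxylic acid on that ring, or a longer chain in place of the methyl of 3-methylphenyl, would behave on this read-out, and whether any such group would stand apart from compound 1 as well as from compound 2.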